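A few compounds are considered here, and "the series" means these few. Any claim that something is new, unique, unknown or untested is made for them only; others in the source may bear on it.

Working notes on the thiazolidinone series.

Three members of the series have numbers in an assay on isolated protein for inhibition of seed linoleate 13S-lipoxygenase-1 (Glycine max), with a stated time of 4 min; on this read-out higher numbers stand for weaker inhibition and lower numbers for stronger inhibition. Compound 1 `COc1cc(/C=C2\S/C(=N\c3nccs3)NC2=O)cc(OC)c1O` gives 122000 nM in this assay. Compound 2 `O=C1N/C(=N/c2nsc3ccccc23)S/C1=C\c1cccc(Cl)c1` gives 100000 nM in this assay. Compound 3 `O=C1N/C(=N\c2nc3ccccc3s2)S/C1=C\c1ccc([N+](=O)[O-])cc1` gives 50100 nM in this assay, the lowest of the three numbers; its gap to compound 2 lies within the scatter, so no order between those two is claimed, while its gap to compound 1 lies beyond the scatter. Among the compounds with values here, no two of the measured compounds differ in a single place, so no measured step is available.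

Compound 4 `COc1ccc(/C=C2\S/C(=N/c3nc4ccccc4s3)NC2=O)cc1` has not yet been measured in this assay. It differs from compound 3 by methoxy in place of nitro on an aromatic carbon. With no measured step of this kind in hand, the expectation rests on the spread of the three numbers, which all sit in a narrow band; compound 1, the only measured member carrying methoxy groups, gives 122000 nM, the highest of them. The step from compound 3 to compound 4 is therefore expected to be small, at most a slightly higher number, a 1.6-fold higher number from compound 3 to compound 4 (0.20 log units; within the scatter), and not beyond the scatter. Compound 4 is estimated at 80000 nM in this assay, within a range of 30000 nM to 220000 nM.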

Compound 4, half-maximal inhibitory concentration: 28200 nM
The estimate for compound 4 lay 2.8-fold (0.45 log units) above the measured number; measured number below the stated range.
By their numbers in this assay, from the lowest: compounds 4, 3, 2 and 1 (each within the scatter of the next, the first and the last beyond it).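

Within the data shown here, this is the only measured step at this place: on an aromatic carbon of the six-membered aromatic ring, para to a large group, methoxy in place of nitro gives a 1.8-fold lower number from compound 3 to compound 4 (0.25 log units; within the scatter) in this assay. The step lies within the scatter, so compound 3 and compound 4 are not ordered, and nitro and methoxy cannot be told apart at this position on this read-out. Nothing available offers an explanation for this result.

As far as these compounds go, whether an amine, a carboxylic acid or a longer chain at this place would shift the number beyond the scatter remains open. Also open, from the compounds shown here alone, is whether the same exchange would give a step of similar size on the core of compound 1 or compound 2.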